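This account rests on a few compounds, and the source may have more. Where it says the series, first, only, none or still open, it means among the compounds named here.

Of the compounds shown here, two of a shared core have been measured in a functional assay on the whole organism (aorta) with Rattus norvegicus as the target; on this read-out higher numbers stand for larger maximal responses and lower numbers for smaller maximal responses. Compound 1, `CC1(C)C=C(n2ccccc2=O)c2cc(S(=O)(=O)N=[N+]=[N-])ccc2O1`, gives 88.3%. Compound 2, `CCNS(=O)(=O)c1ccc2c(c1)C(n1ccccc1=O)=CC(C)(C)O2`, gives 72.4%. For the measured compounds named here, the one step between them, a number 15.9 percentage points lower from compound 1 to compound 2 (beyond the scatter), is the only measured step in this set, and it leaves compound 2 as the lower of the two numbers, with compound 1 the nearest neighbour and above it beyond the scatter.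

Compound 3, `CC(C)NS(=O)(=O)c1ccc2c(c1)C(n1ccccc1=O)=CC(C)(C)O2`, differs from compound 2 in a single place: methyl in place of hydrogen on a saturated chain carbon bound to a saturated chain carbon and a sulfonamide nitrogen. Going by the values given here, no measured step bears directly on this change; the one step that exists exchanges a whole group on the sulfonyl sulfur, whereas here only a methyl enters on the saturated chain carbon bound to a saturated chain carbon and a sulfonamide nitrogen. With nothing comparable to draw on, a step no larger than the scatter is expected from compound 2 to compound 3, a number 2.4 percentage points lower from compound 2 to compound 3 (within the scatter), in either direction. Compound 3 is therefore estimated to give 70% in this assay, within a range from 55% to 85%.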

Compound 3, largest response reached (Emax), in percent of the reference or control that the assay uses: 76.9%
For compound 3 the middle estimate is 6.9 percentage points below the measured one; the range from low to high includes it.
By their numbers in this assay, from the lowest: compounds 2 and 3 (each within the scatter of the next); then compound 1.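

In this assay, methyl in place of hydrogen on a saturated chain carbon bound to a saturated chain carbon and a sulfonamide nitrogen gives a number 4.5 percentage points higher from compound 2 to compound 3 (within the scatter) and so does not separate ethylamino from isopropylamino on the sulfonyl sulfur, a comparison that the earlier pair could not offer. Isopropylamino in place of azido gives a number 11.4 percentage points lower from compound 1 to compound 3 (beyond the scatter) and thus repeats what ethylamino showed with a number 15.9 percentage points lower from compound 1 to compound 2 (beyond the scatter) in this assay: both of these amino groups on the sulfonyl sulfur stand apart from azido by more than the scatter, and neither of the two steps goes against this. What lies behind these steps is not addressed by any evidence at hand.

From the compounds shown here alone, it remains open whether a longer chain such as n-butyl, a bulkier group such as tert-butyl or a ring such as cyclohexyl on the sulfonamide nitrogen would also stay within the scatter of compound 2 and compound 3. Going by these compounds, it is equally open whether a plain amino group or a morpholine ring on the sulfonyl sulfur would fall with these two compounds or come closer to compound 1.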